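This account rests on a few compounds, and the source may have more. Where it says the series, first, only, none or still open, it means among the compounds named here.

Compound 1 `CC1=C(C(=O)OCc2ccccc2)C(c2ccoc2)NC(=O)N1`: 41%
Compound 2 `CC1=C(C(=O)OC(C)(C)C)C(c2cccs2)NC(=O)N1`: 26%

The two measured compounds share a core and differ in two places at once, in the ester group and in the ring attached to the core. In an assay on membranes from CHO cells for displacement of a labelled ligand from adenosine receptor A1 (Homo sapiens), read by scintillation counting, with a stated time of 60 min, tested at 1 uM (on this read-out higher numbers stand for more inhibition at the one concentration tested (going by the name of the read-out) and lower numbers for less inhibition), compound 1 gives 41%, while compound 2 gives 26%. Compound 2 therefore stands lowest of the two numbers, and its nearest neighbour, compound 1, lies higher by a margin beyond the usual scatter.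

Compound 3 `CC1=C(C(=O)OCc2ccccc2)C(c2cccs2)NC(=O)N1` has not yet been measured in this assay. It differs from compound 2 in one place: benzyl in place of tert-butyl on an oxygen next to a carbonyl group. Within the data shown here, the benzyl ester is the one carried by compound 1, while the ring on the core is that of compound 2, so compound 3 sits between the two measured compounds in structure. Among the measured compounds shown here, no pair of measured compounds isolates this ester change on its own. The expected step is a number 11 percentage points higher from compound 2 to compound 3 (beyond the scatter), a rise that is expected to go beyond the scatter but to stay short of the full gap to compound 1, because compound 1 gives 41% with the same benzyl group but a different ring. Compound 3 is estimated at 37%, with a likely range from 22% to 52%.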

Compound 3, a percentage reported as inhibition, at one concentration (the size of the read-out at that concentration, not a potency): 45%
Compound 3: the middle estimate sits 8 percentage points below what was measured; low and high end bracket the measured number.
By their numbers in this assay, from the lowest: compound 2; then compounds 1 and 3 (each within the scatter of the next).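

In this assay, among these compounds, benzyl in place of tert-butyl on an oxygen next to a carbonyl group gives a number 19 percentage points higher from compound 2 to compound 3 (beyond the scatter) and so gives the first reading of this ester change on its own, with the ring on the shared core held as thiophen-2-yl. With the benzyl ester held fixed, thiophen-2-yl in place of furan-3-yl on a saturated ring carbon gives a number 4 percentage points higher from compound 1 to compound 3 (within the scatter) and shows that, at this single concentration, these two rings cannot be told apart on this read-out. Nothing measured here speaks to why the benzyl ester reads higher than the tert-butyl ester.

The compounds shown leave open whether the ester step carries over to the furan-3-yl ring, and whether it is tied to the aromatic ring of the benzyl group or would also appear with a cyclohexylmethyl group on that oxygen. On these data alone, how a methyl, an ethyl or a longer chain such as phenethyl on that oxygen would read in this assay also stays open.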